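A few compounds are considered here, and "the series" means these few. Any claim that something is new, unique, unknown or untested is made for them only; others in the source may bear on it.

Series notes. Three compounds built on a shared core have numbers in an assay for inhibition of steroid 17-alpha-hydroxylase/17,20 lyase (Rattus norvegicus), read by LC-MS, using microsomes; on this read-out higher numbers stand for weaker inhibition and lower numbers for stronger inhibition. Compound 1 `COc1cc2ccc(C(O)(c3cc[nH]n3)C(C)C)cc2cc1OC` gives 1600 nM; compound 2 `COc1cc2ccc(C(O)(c3nc[nH]n3)C(C)C)cc2cc1OC` gives 7100 nM; compound 3 `COc1cc2ccc(C(O)(c3ccncc3)C(C)C)cc2cc1OC` gives 60 nM. Compound 3 stands lowest of the three: the step of a 27-fold lower number from compound 1 to compound 3 (1.43 log units; beyond the scatter) and the step of a 120-fold lower number from compound 2 to compound 3 (2.07 log units; beyond the scatter) both lie beyond the scatter, so pyridin-4-yl gives the lowest number of the groups seen so far at this carbon.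

Compound 4 `COc1cc2ccc(C(O)(c3ccncn3)C(C)C)cc2cc1OC` is not yet measured. Against compound 3 the change is pyrimidin-4-yl in place of pyridin-4-yl on a saturated chain carbon bound to an aromatic carbon, an oxygen on a saturated carbon and a saturated chain carbon. Among the measured compounds shown here, no measured step exchanges one such group for another of the same ring size, so the only precedent is a 4.4-fold higher number from compound 1 to compound 2 (0.65 log units; beyond the scatter), where 1H-1,2,4-triazol-3-yl in place of 1H-pyrazol-3-yl at the same carbon gave a modest rise beyond the scatter. By that analogy a modest rise in this assay is expected from compound 3 to compound 4, well short of the gaps separating compound 3 from compound 1 and compound 2, so compound 4 should remain nearer compound 3 than compound 1. The estimate for compound 4 is 200 nM (range 60 nM to 700 nM). The step this implies in this assay is expected to be a 3.3-fold higher number from compound 3 to compound 4 (0.52 log units; beyond the scatter).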

Compound 4, half-maximal inhibitory concentration: 440 nM
For compound 4 the middle estimate is 2.2-fold (0.34 log units) below the measured one; measured number inside the range.
By their numbers in this assay, from the lowest: compound 3; then compound 4; then compound 1; then compound 2.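

Working notes on this assay: the step of a 7.3-fold higher number from compound 3 to compound 4 (0.87 log units; beyond the scatter), with pyrimidin-4-yl in place of pyridin-4-yl, is the first exchange here of one six-membered aromatic ring for another, and it shows that this carbon responds to the ring's hetero atoms even at an unchanged heavy-atom count. Pyrimidin-4-yl nevertheless keeps a clear lead over the other two groups, with a 3.6-fold lower number from compound 1 to compound 4 (0.56 log units; beyond the scatter) and a 16-fold lower number from compound 2 to compound 4 (1.21 log units; beyond the scatter), so the order at this carbon is now pyridin-4-yl, pyrimidin-4-yl, 1H-pyrazol-3-yl, 1H-1,2,4-triazol-3-yl, with each neighbouring pair separated beyond the scatter. The rise on adding a ring nitrogen now appears in two separate exchanges, this one and a 4.4-fold higher number from compound 1 to compound 2 (0.65 log units; beyond the scatter), and none of the four compounds goes against that direction.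

The compounds shown leave open whether pyridin-3-yl, pyrimidin-5-yl or a plain phenyl ring at this carbon would fit that order, and whether an amine on the pyridin-4-yl ring would move the number in either direction. Nothing available here gives a reason for the order of these groups.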